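Lengthening the hydroxycarbamoyl tail of compound 1

The source may hold more compounds than are shown below. What is called first, only, known or untested is meant among the compounds shown, and "the series" means these compounds.

Compounds measured in a functional assay on MV4-11 cells (Homo sapiens) for inhibition, read by CellTiter-Glo, with a stated time of 48 h; a lower number here means a stronger inhibitor of growth, a higher number a weaker inhibitor of growth:
- compound 1 `O=C(CCCCC(=O)N1C/C=C/COCc2cccc(c2)-c2ccnc(n2)Nc2cccc(c2)C1)NO`: 2060 nM
- compound 2 `O=C(CCCCN1C/C=C/CCOc2cccc(c2)-c2ccnc(n2)Nc2cccc(c2)C1)NO`: 660 nM
- compound 3 `O=C(CCCCC(=O)N1C/C=C/CCOc2cccc(c2)-c2ccnc(n2)Nc2cccc(c2)C1)NO`: 1010 nM

Compound 1 gives the highest number of the three at 2060 nM, which makes it the weakest inhibitor of growth in this small set. Its gaps to compound 2 and compound 3 both lie beyond the scatter.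

Compound 4 `O=C(CCCCCCC(=O)N1C/C=C/COCc2cccc(c2)-c2ccnc(n2)Nc2cccc(c2)C1)NO` keeps the core of compound 1 and changes only the tail: 2-(hydroxycarbamoyl)ethyl in place of hydroxycarbamoyl on a saturated chain carbon, four bonds along the chain from a carbonyl carbon. Within the data shown here, no measured pair differs in this way, so there is no direct precedent. The nearest evidence is a change on an amine nitrogen in a ring, a 1.5-fold higher number from compound 2 to compound 3 (0.18 log units; within the scatter), and that step stays within the scatter. Among the measured compounds shown here, with only that small step to go on, and with compound 1 already at 2060 nM, a modest move to a lower number is expected, not a large one.

For compound 4 the estimated step is a 1.6-fold lower number from compound 1 to compound 4 (0.20 log units; within the scatter).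

For compound 4 the expected value is 1300 nM, with an estimated range from 450 nM to 3200 nM.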

Compound 4, concentration for 50% growth inhibition: 1410 nM
Beside the measured number, compound 4's estimate is 1.1-fold (0.04 log units) below it; low and high end bracket the measured number.
By their numbers in this assay, from the lowest: compounds 2, 3, 4 and 1 (each within the scatter of the next, the first and the last beyond it).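

In this assay, among these compounds, this is the first direct reading of 2-(hydroxycarbamoyl)ethyl in place of hydroxycarbamoyl on a saturated chain carbon, four bonds along the chain from a carbonyl carbon, and it comes out as a 1.5-fold lower number from compound 1 to compound 4 (0.16 log units; within the scatter). The tail of compound 1 can therefore take this added length with the number staying within the scatter, which compound 2 and compound 3, differing from each other only on the ring nitrogen, could not show. No measurement given here bears on why the added length leaves the number within the scatter.

The compounds shown leave open whether a still longer chain at this place would also stay within the scatter of compound 1, and whether a carboxylic acid could stand in for the hydroxycarbamoyl end. They also leave open whether the same lengthening would read alike on the core of compound 3.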